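A Bromine-for-Fluorine Swap on the Aniline Ring

The compounds below may be only part of what the source reports. "The series", "measured", "known", "first", "only" and "open" are said of these compounds alone.

Of the compounds shown here, three sharing one core have been measured in a functional assay on NCI-H1975 cells (Homo sapiens) for inhibition, read by MTT assay, with a stated time of 72 h; on this read-out higher numbers stand for weaker inhibition and lower numbers for stronger inhibition. Compound 1 `O=C(CSc1nc(Nc2ccccc2)c2ccccc2n1)Nc1cccc([N+](=O)[O-])c1` gives 17900 nM, compound 2 `O=C(CSc1nc(Nc2ccccc2)c2ccccc2n1)Nc1ccc(Cl)c(Cl)c1` gives 10400 nM, and compound 3 `C=CC(=O)Nc1cccc(NC(=O)CSc2nc(Nc3ccccc3F)c3ccccc3n2)c1` gives 6580 nM. Compound 3 has the lowest of the three numbers; its gap to compound 2 lies within the scatter, while its gap to compound 1 lies beyond it. Going by the values given here, the only single-point step among the measured compounds, a 1.7-fold lower number from compound 1 to compound 2 (0.24 log units; within the scatter), concerns the amide-type nitrogen, not the position changed here.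

Compound 4 `C=CC(=O)Nc1cccc(NC(=O)CSc2nc(Nc3cccc(Br)c3)c3ccccc3n2)c1` differs from compound 3 by 3-bromophenyl in place of 2-fluorophenyl on a nitrogen on an aromatic ring. Among the compounds with values here, no measured step touches that nitrogen, so nothing in the data speaks for a shift in either direction. The step of a 1.0-fold lower number from compound 3 to compound 4 (0.01 log units; within the scatter) is therefore expected to stay within the scatter. Compound 4 is estimated to give 6500 nM in this assay, with a plausible range from 2500 nM to 17000 nM.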

Compound 4, half-maximal inhibitory concentration: 12100 nM
Compound 4: middle estimate off by 1.9-fold (0.27 log units), on the low side; the range from low to high includes it.
By their numbers in this assay, from the lowest: compounds 3, 2, 4 and 1 (each within the scatter of the next, the first and the last beyond it).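

In this assay, going by these compounds alone, the step of a 1.8-fold higher number from compound 3 to compound 4 (0.26 log units; within the scatter) is the first reading of a change on this nitrogen, and it lies within the scatter. At this position, then, 3-bromophenyl and 2-fluorophenyl cannot be told apart in this cell read-out, although the halogen and its place on the ring both differ in this single step, which leaves their separate contributions unresolved. No measurement at hand offers an explanation for this result.

Still open, on these data alone, is how a ring on this nitrogen would read with a group other than a halogen, such as a methoxy group, an amine or a carboxylic acid. Also open, as far as these compounds go, is whether bromine and fluorine would read alike if each were compared at the same place on the ring.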